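The source may report more compounds than this note shows. Statements on the series, on what has been measured and on what is new or still open speak of the compounds shown alone.

Of the compounds shown here, three built on the shared core have been measured in an assay on CHO-K1 cells for displacement of a labelled ligand from prostaglandin E2 receptor EP1 subtype (Homo sapiens); on this read-out higher numbers stand for weaker inhibition and lower numbers for stronger inhibition. Compound 1 `CNC(=O)c1cc(C)n(Cc2cc(Cl)ccc2OCc2ccccc2)n1` gives 100 nM. Compound 2 `Cc1cc(C(=O)Nc2cccc(F)c2)nn1Cc1cc(Cl)ccc1OCc1ccccc1` gives 200 nM; the change from methyl to 3-fluorophenyl reads a 2.0-fold higher number from compound 1 to compound 2 (0.30 log units; within the scatter). Compound 3 `Cc1cc(C(=O)Nc2c(F)cccc2F)nn1Cc1cc(Cl)ccc1OCc1ccccc1` gives 10 nM, the lowest of the three numbers, with a 10-fold lower number from compound 1 to compound 3 (1.00 log units; beyond the scatter) and a 20-fold lower number from compound 2 to compound 3 (1.30 log units; beyond the scatter).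

Compound 4 `Cc1cc(C(=O)Nc2ccccn2)nn1Cc1cc(Cl)ccc1OCc1ccccc1` has not been measured. It differs from compound 3 in one place: pyridin-2-yl in place of 2,6-difluorophenyl on an amide-type nitrogen. Going by the values given here, two measured steps bear on this change. The step of a 20-fold lower number from compound 2 to compound 3 (1.30 log units; beyond the scatter) shows that the 2,6-difluorophenyl went with a large gain over a 3-fluorophenyl, while the step of a 2.0-fold higher number from compound 1 to compound 2 (0.30 log units; within the scatter) shows that a fluorophenyl without that pattern stayed within the scatter of methyl. Compound 4 keeps a six-membered aromatic ring on the amide nitrogen but gives up the fluorines of the 2,6-difluorophenyl, so a weaker result than compound 3 is expected, an 8.0-fold higher number from compound 3 to compound 4 (0.90 log units; beyond the scatter), though not as weak as compound 2. The estimated value for compound 4 is 80 nM, with a range from 20 nM to 400 nM.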

Compound 4, half-maximal inhibitory concentration: 126 nM
Estimate against measurement, compound 4: 1.6-fold (0.20 log units) below; the range from low to high includes it.
By their numbers in this assay, from the lowest: compound 3; then compounds 1, 4 and 2 (each within the scatter of the next).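

Replacing the 2,6-difluorophenyl with pyridin-2-yl gives a 13-fold higher number from compound 3 to compound 4 (1.10 log units; beyond the scatter), so a six-membered aromatic ring on the amide-type nitrogen is not enough to keep the low number of compound 3. The other two changes, a 1.6-fold lower number from compound 2 to compound 4 (0.20 log units; within the scatter) and a 1.3-fold higher number from compound 1 to compound 4 (0.10 log units; within the scatter), both stay within the scatter, which leaves only the 2,6-difluorophenyl standing apart among these four compounds. Nothing measured here explains why this one group differs from the rest.

Still open, from the compounds shown here alone, is whether fluorine itself matters or whether a 2,6-dichlorophenyl or 2,6-dimethylphenyl on the same nitrogen would give a similarly low number. A non-aromatic ring such as cyclohexyl in that place would also show whether the aromatic ring is needed at all.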